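This account rests on a few compounds, and the source may have more. Where it says the series, first, only, none or still open, it means among the compounds named here.

Measured so far:
compound 1, `C#CCN(C)CC(O)COc1cccc2ccccc12`, 32%
compound 2, `C#CCNCC(O)COc1ccccc1-c1ccccc1`, 27%

Both compounds were tested in an assay on isolated protein for inhibition of Amine oxidase [flavin-containing] B (Homo sapiens), read by fluorescence, with a stated time of 1 h, tested at 100 uM; on this read-out lower numbers stand for less inhibition and higher numbers for more inhibition at the one concentration tested (going by the name of the read-out). Compound 2 stands lowest of the two numbers, and its nearest neighbour, compound 1, sits within the usual scatter of it, so the two cannot be told apart. Compound 3, `C#CCN(C)CC(O)COc1ccccc1-c1ccccc1`, has not been measured. It differs from compound 2 in one place: methyl in place of hydrogen on an amine nitrogen. Within the data shown here, no step between measured compounds is available to lean on, so nothing beyond the scatter is expected, and the step of a number 3 percentage points higher from compound 2 to compound 3 (within the scatter) is estimated to stay small. Compound 3 is expected to give 30%, with a range from 15% to 45%.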

Compound 3, a percentage reported as inhibition, at one concentration (the size of the read-out at that concentration, not a potency): 30%
Compound 3: middle estimate and measured number agree at the digits printed; the range from low to high includes it.
By their numbers in this assay, from the lowest: compounds 2, 3 and 1 (each within the scatter of the next).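

Among these compounds, this is the first step in the set that changes only one place, so it gives a direct reading of the amine nitrogen. In this assay, methyl in place of hydrogen gives a number 3 percentage points higher from compound 2 to compound 3 (within the scatter), so propargylamino and methyl(propargyl)amino cannot be told apart on this core at the one concentration tested. No other data bear on this result.

Going by these compounds, whether a longer chain such as ethyl or a benzyl group on this nitrogen would also leave the number unchanged remains open. So does the effect of removing the propargyl group.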